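The source may report more compounds than this note shows. Statements on the series, on what has been measured and on what is new or still open speak of the compounds shown alone.

The series rests on a shared core, seen in compound 1, `Cn1c(=O)[nH]c2c(cnn2-c2cccc(Cl)c2)c1=N`, and compound 2, `Cn1c(=O)[nH]c2c(cnn2-c2cccc(F)c2)c1=N`. In an assay on membranes from brain for binding affinity to adenosine receptor A1 (Rattus norvegicus), read by radioligand binding, tested at 20 uM (a lower number here means less inhibition, a higher number more inhibition at the concentration tested (going by the name of the read-out)), compound 1 gives 53%. In this assay compound 2 gives 44%. Among the measured compounds shown here, the one measured step, a number 9 percentage points lower from compound 1 to compound 2 (within the scatter), goes with fluoro in place of chloro on an aromatic carbon, so the numbers of compound 1 and compound 2 lie within the scatter of each other and neither can be set apart from the other. For the measured compounds named here, compound 3, `Cn1c(=O)[nH]c2c(cnn2-c2cccc(N)c2)c1=N`, is not yet measured in this assay. amino in place of fluoro on an aromatic carbon The only step that bears on this change is a number 9 percentage points lower from compound 1 to compound 2 (within the scatter), a swap of one halogen for another, and it says nothing directly about an amino group; no measured step in this set puts amino in place of a halogen. With so little to go on, compound 3 is expected to show a step of a number 1 percentage points higher from compound 2 to compound 3 (within the scatter), not beyond the scatter. Compound 3 is therefore estimated at 45% in this assay, within a range from 25% to 65%.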

Compound 3, a percentage reported as inhibition, at one concentration (the size of the read-out at that concentration, not a potency): 0%
The estimate for compound 3 lay 45 percentage points above the measured number, outside the stated range (below it).
By their numbers in this assay, from the lowest: compound 3; then compounds 2 and 1 (each within the scatter of the next).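

Where the earlier pair showed only that chloro and fluoro could not be set apart in this assay, amino in place of fluoro gives a number 44 percentage points lower from compound 2 to compound 3 (beyond the scatter) on the same aromatic carbon, and amino in place of chloro gives a number 53 percentage points lower from compound 1 to compound 3 (beyond the scatter) at that place. This position, on a six-membered aromatic ring of carbon only and meta to a large group, is therefore not indifferent to the group it carries, and among the three compounds the amino group alone stands apart, while the two halogens remain within the scatter of each other. The computed change from fluoro to amino is one of a single heavy atom, with a hydrogen-bond donor and a hydrogen-bond acceptor entering and no net charge, but no measurement given here bears on why the number falls so far.

The compounds shown leave open whether this fall belongs to the amino group alone or would also come with a hydroxyl, a methoxy or a methyl at the same place. They also leave open whether a methylamino or an acetamido group would stay with amino or move towards the halogens.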